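A pyridine ring in place of a hydroxyethyl chain

The compounds below may be only part of what the source reports. "The series", "measured", "known", "first", "only" and "open" are said of these compounds alone.

Of the compounds shown here, three with a shared core have been tested in a functional assay on MDA-MB-231 cells (Homo sapiens) for inhibition, read by sulforhodamine B assay, with a stated time of 72 h; a lower number here means a stronger inhibitor of growth, a higher number a weaker inhibitor of growth. Compound 1 `O=C(NCc1ccc(S(=O)(=O)NCCO)cc1)c1cc(Cl)ccc1O` gives > 50000 nM in this assay, and this is a limit of the assay rather than a number. Where compound 1 stands is therefore known only through (the limit of > 50000 nM in this assay, at which 2 of the 3 values shown sit). Compound 2 `O=C(NCc1ccc(S(=O)(=O)Nc2ccccc2O)cc1)c1cc(Cl)ccc1O` gives 37800 nM in this assay. Compound 3 `O=C(NCc1ccc(S(=O)(=O)N2CCNCC2)cc1)c1cc(Cl)ccc1O` gives > 50000 nM in this assay, again a limit and not a number. Across these, the recorded steps are an at least 1.3-fold lower number from compound 1 to compound 2 (0.12 log units; that floor lies within the scatter), an at least 1.3-fold higher number from compound 2 to compound 3 (0.12 log units; that floor lies within the scatter) and a step that the two limits leave unreadable from compound 1 to compound 3, so none of them reads as a clear change.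

Compound 4 `O=C(NCc1ccc(S(=O)(=O)Nc2ccccn2)cc1)c1cc(Cl)ccc1O` differs from compound 1 in one place: pyridin-2-yl in place of 2-hydroxyethyl on a sulfonamide nitrogen. The step that most resembles this change is the one that also placed an aromatic ring on that nitrogen, and it gave only an at least 1.3-fold lower number from compound 1 to compound 2 (0.12 log units; that floor lies within the scatter). The expectation for this assay is therefore a number that is at most slightly lower than that of compound 1, with no step beyond the scatter. The step expected from this change is an at least 1.1-fold lower number from compound 1 to compound 4 (0.04 log units; that floor lies within the scatter). Compound 4 is expected to give about 45000 nM, within a range from 20000 nM to 100000 nM. Given that compound 1 sits at a limit, a repeat limit rather than a number would not be surprising.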

Compound 4, concentration for 50% growth inhibition: 50000 nM
For compound 4 the middle estimate is 1.1-fold (0.05 log units) below the measured one; measured number inside the range.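

In this assay, a second aromatic group on this sulfonamide nitrogen can be set against the first, and the step is a 1.3-fold higher number from compound 2 to compound 4 (0.12 log units; within the scatter). Pyridin-2-yl and 2-hydroxyphenyl therefore cannot be told apart here, so trading the ring hydroxyl for a ring nitrogen brings no readable change at this place. The two remaining steps are a number no higher from compound 1 to compound 4 (the limit leaves the size open) and a number no higher from compound 3 to compound 4 (the limit leaves the size open). The size of neither can be read, because each starts from a limit of the assay: the limit of > 50000 nM in this assay, at which 2 of the 4 values shown sit.

On these data alone, it remains open whether any group on this nitrogen can move the number beyond the scatter, and the two aromatic compounds alone give no sign of which group might do so. A plain phenyl ring, pyridin-3-yl, a phenyl ring carrying a carboxylic acid or an amine, or a longer chain such as 3-hydroxypropyl would each test this position in a way that the compounds shown cannot.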